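This account rests on a few compounds, and the source may have more. Where it says the series, first, only, none or still open, it means among the compounds named here.

Compound 1 `O=C(NCc1ccc(CNS(=O)(=O)c2cccc(Cl)c2)cc1)c1ccc(F)cc1` and compound 2 `O=C(NCc1ccc(CNS(=O)(=O)c2cccc(F)c2)cc1)c1ccc(F)cc1` share a core and differ only on the ring attached to the sulfonyl sulfur. In an assay on MDA-MB-231 cells for binding affinity to C-X-C chemokine receptor type 4 (Homo sapiens), read by fluorescence and microscopy, with stated times of 10 min and 30 min (on this read-out lower numbers stand for an effect already at smaller amounts and higher numbers for an effect only at larger amounts of compound), compound 1 gives 1 nM, while compound 2 gives 1000 nM; compound 2 thus stands highest of the two numbers, and the step of a 1000-fold higher number from compound 1 to compound 2 (3.00 log units; beyond the scatter) is large. Compound 3 `O=C(NCc1ccc(CNS(=O)(=O)c2ccc3c(c2)CCO3)cc1)c1ccc(F)cc1` has not yet been measured. Relative to compound 2 the change is a group of 9 heavy atoms (8 carbon, 1 oxygen; one five-membered non-aromatic ring with 1 hetero atom, one six-membered aromatic ring of carbon only) in place of a group of 7 heavy atoms (6 carbon, 1 fluorine; one six-membered aromatic ring of carbon only), on a sulfonyl sulfur. Within the data shown here, the only step that bears on this position is the one from compound 1 to compound 2, which showed that a small swap on this ring can move the number a great deal. The entering group is larger than the fluorine it replaces, so a lower number than that of compound 2 is expected, but with wide uncertainty. For compound 3 the expected result is 100 nM, within 5 nM to 2000 nM, meaning an expected step of a 10-fold lower number from compound 2 to compound 3 (1.00 log units; beyond the scatter).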

Compound 3, effective concentration (reported as EC, without a stated level of effect): 10 nM
For compound 3 the middle estimate is 10-fold (1.00 log units) above the measured one, and the stated range covers the measured number.
By their numbers in this assay, from the lowest: compound 1; then compound 3; then compound 2.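

In this assay, putting the group with the five-membered non-aromatic ring in place of 3-fluorophenyl on the sulfonyl sulfur gives a 100-fold lower number from compound 2 to compound 3 (2.00 log units; beyond the scatter), so a larger group with two rings can sit at this position and still give a low number. Set against the chlorine-bearing group, the same group gives a 10-fold higher number from compound 1 to compound 3 (1.00 log units; beyond the scatter), so a low number here does not depend on chlorine, although compound 3 does not match compound 1. Nothing available explains why these groups differ.

Still open, on these data alone, is whether the oxygen or the extra ring accounts for the gain over compound 2. It is also unclear how an unsubstituted phenyl group, or a phenyl ring carrying an amine or a carboxylic acid, would behave on the sulfonyl sulfur.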